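The source may report more compounds than this note shows. Statements on the series, on what has been measured and on what is new or still open speak of the compounds shown alone.

In a functional assay on cells (Platelet, Homo sapiens) for inhibition (on this read-out lower numbers stand for stronger inhibition and higher numbers for weaker inhibition), compound 1 (`CCOC(=O)c1ccc(-c2nn(Cc3ccccc3OC)c3ccccc23)cc1`) stands at > 10000 nM as a limit of the assay. Compound 2 (`CCOC(=O)c1ccc(-c2nn(Cc3ccncc3)c3ccccc23)cc1`) gives > 10000 nM as a limit too. Compound 3 (`NC(=O)c1ccc(-c2nn(Cc3ccccc3)c3ccccc23)cc1`) likewise gives only the limit > 10000 nM and no number. It therefore stands with the others at the limit of > 10000 nM in this assay, at which 3 of the 3 values shown sit, and no order among them can be read. Compound 4 (`OCc1ccc(-c2nn(Cc3ccccc3)c3ccccc23)cc1`) carries hydroxymethyl in place of carbamoyl on an aromatic carbon and is otherwise identical to compound 3. The data hold only a step that the two limits leave unreadable from compound 1 to compound 2 at another place, which sets no size for this change. Compound 3 offers just the limit > 10000 nM as a starting point, so no firm direction can be expected in this assay. The expected step is a step that the limit leaves unreadable from compound 3 to compound 4 as a rough estimate. In this assay compound 4 is expected at 12000 nM within a range from 3000 nM to 40000 nM as an estimate.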

Compound 4, half-maximal inhibitory concentration: > 10000 nM
Compound 4: no number, only a limit; the forecaster's own chance of this, stated with the estimate: 65%; the middle value does not contradict the limit.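

In this assay, among these compounds, compound 4 gives > 10000 nM, which is a limit of the assay, so no step from compound 3 to it can be read. The compounds shown leave open any order among them and the size of any change: the limit of > 10000 nM in this assay, at which 4 of the 4 values shown sit.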